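Removing One Trifluoromethyl from a Urea Growth Inhibitor

A few compounds are considered here, and "the series" means these few. Any claim that something is new, unique, unknown or untested is made for them only; others in the source may bear on it.

Among the measured compounds shown here, compound 1 `COc1cc(-c2nn(-c3cccc(NC(=O)Nc4cc(C(F)(F)F)cc(C(F)(F)F)c4)c3)cc2-c2ccncc2)ccc1Cl` holds the lower of the two numbers measured so far: in a functional assay on NCI-H460 cells (Homo sapiens) for inhibition, read by sulforhodamine B assay, with a stated time of 48 h (on this read-out lower numbers stand for stronger inhibition of growth and higher numbers for weaker inhibition of growth), compound 1 gives 558 nM. Compound 2 `O=C(Nc1cccc(-n2cc(-c3ccncc3)c(-c3ccc(Cl)c(O)c3)n2)c1)Nc1ccc(Cl)c(Cl)c1` gives 993 nM in this assay, and the two values lie within the scatter of each other. From the compounds shown here alone, compound 3 `COc1cc(-c2nn(-c3cccc(NC(=O)Nc4cccc(C(F)(F)F)c4)c3)cc2-c2ccncc2)ccc1Cl` is still untested. It differs from compound 1 by hydrogen in place of trifluoromethyl on an aromatic carbon. For the measured compounds named here, no measured step of this kind is available, so the expectation rests on the change alone: the estimated step of a 1.7-fold higher number from compound 1 to compound 3 (0.23 log units; within the scatter) is expected to point toward weaker inhibition, at about the edge of the scatter. Compound 3 is therefore estimated at 950 nM, between 350 nM and 2600 nM.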

Compound 3, concentration for 50% growth inhibition: 763 nM
Estimate against measurement, compound 3: 1.2-fold (0.10 log units) above; the measured number falls inside the stated range.
By their numbers in this assay, from the lowest: compounds 1, 3 and 2 (each within the scatter of the next).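

In this assay, among the compounds shown here, hydrogen in place of trifluoromethyl on this aromatic carbon gives a 1.4-fold higher number from compound 1 to compound 3 (0.14 log units; within the scatter) and so provides the first single change that can be read, with one trifluoromethyl group remaining on the ring in compound 3. At this position, the loss of these four heavy atoms leaves the two compounds within the scatter of each other. No available measurement explains this result. From the compounds shown here alone, it remains open whether an amine or a carboxylic acid on this carbon would give a step beyond the scatter, and what replacing the remaining trifluoromethyl group would do.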